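Chloro in Place of Trifluoromethyl: an Expected Activity Value

The source may hold more compounds than are shown below. What is called first, only, known or untested is meant among the compounds shown, and "the series" means these compounds.

Measured compounds in a functional assay on UO-31 cells (Homo sapiens) for inhibition, read by sulforhodamine B assay, with a stated time of 48 h, tested at 10 uM; on this read-out higher numbers stand for a weaker effect at the one concentration tested and lower numbers for a stronger effect:
compound 1 `COc1cc(Cl)cc(-c2nn(-c3cccc(NC(=O)c4ccc(Cl)c(Cl)c4)c3)cc2-c2ccncc2)c1`: 43.5%
compound 2 `O=C(Nc1cccc(-n2cc(-c3ccncc3)c(-c3cc(O)cc(Cl)c3)n2)c1)Nc1ccc(Cl)c(C(F)(F)F)c1`: 18.5%

Of the two measured compounds, compound 2 stands lowest in this assay, which on this read-out means the stronger effect; its nearest neighbour is compound 1, whose number lies higher by a gap that exceeds the usual scatter. Compound 3 `O=C(Nc1cccc(-n2cc(-c3ccncc3)c(-c3cc(O)cc(Cl)c3)n2)c1)Nc1ccc(Cl)c(Cl)c1` has not yet been measured. It differs from compound 2 in one place: chloro in place of trifluoromethyl on an aromatic carbon. The trifluoromethyl gives way to a chloro ortho to a chloro group already present, so that the 4-chloro-3-(trifluoromethyl)phenyl of compound 2 becomes a 3,4-dichlorophenyl in compound 3. For the measured compounds named here, no pair of measured compounds that differ in a single place is available, so no measured step can guide the estimate, and the expectation rests only on the value of compound 2 and the modest extent of the change. In this assay the step is expected to be small, a number 6.5 percentage points higher from compound 2 to compound 3 (within the scatter), most likely within the scatter, with a slight lean toward a weaker effect. Compound 3 is therefore estimated at 25%, with a range from 10% to 45%.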

Compound 3, a percentage reported as activity, at one concentration (the size of the read-out at that concentration, not a potency): -41.3%
Compound 3: the middle estimate sits 66.3 percentage points above what was measured, and the stated range ends above it.
By their numbers in this assay, from the lowest: compound 3; then compound 2; then compound 1.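

In this assay, chloro in place of trifluoromethyl, on an aromatic carbon ortho to a chloro group, proves to be far from a minor exchange: it gives a number 59.8 percentage points lower from compound 2 to compound 3 (beyond the scatter), so the 3,4-dichlorophenyl end carries a much stronger effect than the 4-chloro-3-(trifluoromethyl)phenyl end. With the rest of the structure unchanged, compound 3 gives -41.3%, the only negative number among the compounds shown, which makes this single position a strong determinant of the read-out at the one concentration tested. No measurement is available that bears on the reason for a step of this size.

Going by these compounds, whether a bromo, a methyl, a methoxy or a plain hydrogen on the same aromatic carbon would behave like chloro or like trifluoromethyl remains open. Compound 1 also carries the 3,4-dichlorophenyl group but differs from compound 3 in more than one place, so the compounds shown leave open whether this step would hold on another linker or with the hydroxy group replaced, and a single-concentration read-out gives no potency for any of them.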